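A few compounds are considered here, and "the series" means these few. Any claim that something is new, unique, unknown or untested is made for them only; others in the source may bear on it.

Compound 3 `CC(C)C(Cc1noc(=O)[nH]1)c1ccc(-c2ccc3cccc(F)c3c2)[nH]c1=O` reads > 3 h in an ADME assay on microsomes from liver (Rattus norvegicus) for metabolic stability (a higher number here means that the compound lasts longer, a lower number that the compound disappears faster), and this value is a limit of the assay, not a number. In the same assay, compound 1 `CC(C)C(Cc1nnc[nH]1)c1ccc(-c2ccc3cccc(F)c3c2)[nH]c1=O` gives 0.1 h and compound 2 `CC(C)C(Nc1nccs1)c1ccc(-c2ccc3cccc(F)c3c2)[nH]c1=O` gives 0.07 h. Compound 4 `CC(C)C(c1noc(=O)[nH]1)c1ccc(-c2ccc3cccc(F)c3c2)[nH]c1=O` has not been measured. It differs from compound 3 as follows: a group of 6 heavy atoms (2 carbon, 2 nitrogen, 2 oxygen; one five-membered aromatic ring with 3 hetero atoms) in place of a group of 7 heavy atoms (3 carbon, 2 nitrogen, 2 oxygen; one five-membered aromatic ring with 3 hetero atoms), on a saturated chain carbon bound to an aromatic carbon and a saturated chain carbon. The five-membered aromatic ring with 3 hetero atoms of compound 3 remains in compound 4.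

Two measured steps lead to compound 3, and both are large: an at least 30-fold higher number from compound 1 to compound 3 (1.47 log units; beyond the scatter), and an at least 42-fold higher number from compound 2 to compound 3 (1.63 log units; beyond the scatter). Both end on the ring group that compound 4 retains, which favours a long half-life for compound 4. The third step, a 1.4-fold lower number from compound 1 to compound 2 (0.15 log units; within the scatter), stays within the scatter, although the group and its attachment both change. For the measured compounds named here, no measured pair isolates the change made here, and the limit on compound 3 leaves the true size of any step open. No step beyond the scatter is therefore expected, and the estimated change is an at least 1.2-fold lower number from compound 3 to compound 4 (0.07 log units; that floor lies within the scatter). For compound 4 the expected half-life is 2.5 h, with an estimated range from 0.5 h to 8 h.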

Compound 4, half-life: > 3 h
Compound 4: only a limit was reported (the forecaster's own chance of this, stated with the estimate: 45%); middle value at least 1.2-fold (0.07 log units) away from the limit.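

In this assay compound 4 gives > 3 h, a limit of the assay and not a number. With the group of 6 heavy atoms on a saturated chain carbon bound to an aromatic carbon and a saturated chain carbon, the five-membered aromatic ring with 3 hetero atoms keeps its large lead over the other groups at this place, without the extra carbon of compound 3: an at least 42-fold higher number from compound 2 to compound 4 (1.63 log units; beyond the scatter) and an at least 30-fold higher number from compound 1 to compound 4 (1.47 log units; beyond the scatter) are both large. The step between compound 3 and compound 4 cannot be read, because both values rest on the same limit: the limit of > 3 h in this assay, at which 2 of the 4 values shown sit.

On these data alone, how far compound 3 and compound 4 each lie past the limit stays open, so the size of this one-carbon change on the half-life remains unknown, and no order between the two can be given. Whether the long half-life belongs to this particular ring also stays open: the compounds shown include no carboxylic acid or amine at this place, and no longer chain carrying the ring.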